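Replacing the phenyl side group in the EP2 agonist series

The source may hold more compounds than are shown below. What is called first, only, known or untested is meant among the compounds shown, and "the series" means these compounds.

Measured so far:
Compound 1 `CC(C)(C)CCC1([C@H](O)/C=C/[C@H]2COC(=O)N2CCSc2nc(C(=O)O)cs2)CCC1`; in an assay on isolated protein for agonist activity at prostaglandin E2 receptor EP2 subtype (Homo sapiens) (on this read-out higher numbers stand for an effect only at larger amounts of compound and lower numbers for an effect already at smaller amounts), compound 1 gives 3700 nM.
Compound 2 `O=C(O)c1csc(SCCN2C(=O)OC[C@@H]2/C=C/[C@@H](O)C2(CCc3ccccc3)CCC2)n1`; in this assay compound 2 gives 160 nM.

Among the compounds with values here, compound 2 stands at the lower of the two numbers in this assay, and the only measured step, a 23-fold lower number from compound 1 to compound 2 (1.36 log units; beyond the scatter), shows that the group on the saturated chain carbon, two bonds along the chain from a saturated ring carbon, moves the read-out a long way. Compound 3 `CCOCCC1([C@H](O)/C=C/[C@H]2COC(=O)N2CCSc2nc(C(=O)O)cs2)CCC1` carries the change (ethoxy in place of phenyl on a saturated chain carbon, two bonds along the chain from a saturated ring carbon). Within the data shown here, no measured pair shows ethoxy at that place, so the step from compound 1 to compound 2 is the only guide: it records a large gain on going to phenyl, and taking phenyl away again is expected to hand back a good part of that gain, with uncertainty because ethoxy is not tert-butyl. For compound 3 an estimated 9.4-fold higher number from compound 2 to compound 3 (0.97 log units; beyond the scatter) is expected in this assay. The estimate for compound 3 is 1500 nM, with a range from 400 nM to 6000 nM.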

Compound 3, half-maximal effective concentration: 29 nM
Estimate against measurement, compound 3: 52-fold (1.71 log units) above; the measured number lies below the stated range.
By their numbers in this assay, from the lowest: compound 3; then compound 2; then compound 1.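

The phenyl ring is not required for a low number at this position in this assay: ethoxy, which has no ring, gives a 5.5-fold lower number from compound 2 to compound 3 (0.74 log units; beyond the scatter), and compared with tert-butyl it gives a 130-fold lower number from compound 1 to compound 3 (2.11 log units; beyond the scatter). Having no ring does not by itself decide the outcome, since the two ring-free groups, ethoxy and tert-butyl, sit at opposite ends of the three compounds, with phenyl in the middle. No available evidence accounts for the order of these three groups on the saturated chain carbon.

As far as these compounds go, it remains open whether the result depends on the ethoxy oxygen or on the chain as a whole. Propoxy, methoxy or an amine at the same place would test how far this result extends.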